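Nitro for chloro on the thiadiazine-fused series

The source may report more compounds than this note shows. Statements on the series, on what has been measured and on what is new or still open speak of the compounds shown alone.

compound 1 `CC(c1ccc(-c2ccccc2)c(F)c1)c1n[nH]c(=S)n1N`: "not active" (no number reported)
compound 2 `CC(c1ccc(-c2ccccc2)c(F)c1)c1nnc2n1N=C(c1ccc(Cl)cc1)CS2`: 5000 nM

In a functional assay on FOCUS cells (Homo sapiens) for inhibition, read by sulforhodamine B assay, with a stated time of 72 h (a lower number here means a stronger inhibitor, a higher number a weaker inhibitor), compound 2 gives 5000 nM. Among the compounds with values here, compound 1 in this assay is recorded as "not active" (no number reported), without a number, so compound 2 holds the only number in the set. Compound 3 `CC(c1ccc(-c2ccccc2)c(F)c1)c1nnc2n1N=C(c1ccc([N+](=O)[O-])cc1)CS2` differs from compound 2 by nitro in place of chloro on an aromatic carbon. Within the data shown here, no measured pair shows this change here. The shift in this assay is expected to stay within the scatter, with no direction favoured, namely no change at the digits printed from compound 2 to compound 3 (within the scatter). Compound 3 is estimated at 5000 nM, expected between 1500 nM and 16000 nM.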

Compound 3, half-maximal inhibitory concentration: 3500 nM
The estimate for compound 3 lay 1.4-fold (0.15 log units) above the measured number, within the range that was stated.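

In this assay, within the data shown here, 4-chlorophenyl to 4-nitrophenyl gives a 1.4-fold lower number from compound 2 to compound 3 (0.15 log units; within the scatter) and so offers the first readable step at this place on the aromatic ring. The ring tolerates nitro in place of chloro here, with the two values staying within the scatter of each other. No measurement bears on why the two groups read alike.

As far as these compounds go, whether an amine or a carboxylic acid at this place would hold the value remains open. This one pair also says nothing about a longer chain there.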